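Replacing the end group of compound 2

A few compounds are considered here, and "the series" means these few. Any claim that something is new, unique, unknown or untested is made for them only; others in the source may bear on it.

Values measured so far in a functional assay on A2780 cells (Homo sapiens) for inhibition, read by sulforhodamine B assay; a higher number here means a weaker inhibitor of growth, a lower number a stronger inhibitor of growth
Compound 1 `c1ccc(-c2ccc(-c3ccc(-c4nc5ccccc5[nH]4)cc3)cc2)cc1` gives 32100 nM
Compound 2 `Cc1ccc2[nH]c(-c3ccc(-c4ccc(-c5ccc(N(C)C)cc5)cc4)cc3)nc2c1` gives 2210 nM

Compound 2 stands lowest of these two numbers, and the distance to the value of compound 1 (32100 nM) lies beyond the scatter. Compound 3 `Cc1ccc2[nH]c(-c3ccc(-c4ccc(-c5cccc(Cl)c5)cc4)cc3)nc2c1` has not yet been measured. It carries 3-chlorophenyl in place of 4-(dimethylamino)phenyl on an aromatic carbon, para to a large group (3-chlorophenyl in place of 4-(dimethylamino)phenyl on an aromatic carbon). Going by the values given here, no measured pair shows this change, so the expectation is uncertain and rests only on the two values and the structures. In this assay a moderate rise is expected from the starting point of compound 2 (2210 nM), meaning a somewhat weaker inhibitor of growth. The estimated step is modest but beyond the scatter (a 2.7-fold higher number from compound 2 to compound 3 (0.43 log units; beyond the scatter)). The expected value for compound 3 is 6000 nM (estimated range 1800 nM to 20000 nM).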

Compound 3, concentration for 50% growth inhibition: 2800 nM
Compound 3: middle estimate off by 2.1-fold (0.33 log units), on the high side; low and high end bracket the measured number.
By their numbers in this assay, from the lowest: compounds 2 and 3 (each within the scatter of the next); then compound 1.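

In this assay, putting 3-chlorophenyl in place of 4-(dimethylamino)phenyl on this aromatic carbon, para to a large group, gives a 1.3-fold higher number from compound 2 to compound 3 (0.10 log units; within the scatter), so the two end groups cannot be told apart here. This pair shows that, on the core of compound 2, growth inhibition in this assay at this level does not depend on the dimethylamino group, since compound 3 carries a chlorine instead and has no hydrogen-bond acceptor in its end group. No measurement bears on why these two different end groups read alike.

This single step changes both the substituent and where it sits on the end ring, so the effect of each remains unseparated. The compounds shown leave open how 4-chlorophenyl, unsubstituted phenyl or an end ring bearing a carboxylic acid would read at this position.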